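Distal amine substituent swaps in a weak-binding benzimidazole carboxamide series

The source may hold more compounds than are shown below. What is called first, only, known or untested is meant among the compounds shown, and "the series" means these compounds.

Measured so far:
compound 1 `CCc1nc2c(C(=O)NCC3CCN(CC(O)CN4CCN(S(C)(=O)=O)CC4)CC3)cccc2[nH]1` — 79400 nM
compound 2 `CC(C)c1nc2c(C(=O)NCC3CCN(CCN4CCN(S(C)(=O)=O)CC4)CC3)cccc2[nH]1` — 100000 nM
compound 3 `COC(=O)N1CCN(CCN2CCC(CNC(=O)c3cccc4[nH]c(C(C)C)nc34)CC2)CC1` — 79400 nM

In an assay on isolated protein for binding affinity to 5-hydroxytryptamine receptor 3A (Homo sapiens) (a higher number here means a weaker inhibitor, a lower number a stronger inhibitor), compound 2 gives the highest of the three numbers, but its gaps to compound 1 and to compound 3 both lie within the scatter, so no order among them can be read. Among the measured compounds shown here, the one single-site step, a 1.3-fold lower number from compound 2 to compound 3 (0.10 log units; within the scatter), touches the same distal end of the chain and moves nothing beyond the scatter.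

Compound 4 `CC(=O)N1CCC(CN2CCC(CNC(=O)c3cccc4[nH]c(C(C)C)nc34)CC2)CC1` carries a larger exchange at that end: 1-acetylpiperidin-4-yl in place of (4-(methylsulfonyl)piperazin-1-yl)methyl on a saturated chain carbon bound to an amine nitrogen in a ring. For the measured compounds named here, no measured pair speaks to this exchange directly; the only neighbouring step showed no movement, and all three numbers sit at the weak end of the scale. Compound 4 is therefore expected to stay close to its parent, a 1.3-fold lower number from compound 2 to compound 4 (0.10 log units; within the scatter). The estimate for compound 4 is 79400 nM, range 25000 nM to 100000 nM.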

Compound 4, inhibition constant: 100000 nM
Compound 4: the middle estimate sits 1.3-fold (0.10 log units) below what was measured, and the stated range covers the measured number.
By their numbers in this assay, from the lowest: compounds 1, 3, 2 and 4 (each within the scatter of the next).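

In this assay, the larger exchange on a saturated chain carbon bound to an amine nitrogen in a ring gives no change at the digits printed from compound 2 to compound 4 (within the scatter) and a 1.3-fold higher number from compound 3 to compound 4 (0.10 log units; within the scatter). Replacing the whole (4-(methylsulfonyl)piperazin-1-yl)methyl group with 1-acetylpiperidin-4-yl therefore produces no readable movement. The earlier swap on the ring nitrogen also moved nothing beyond the scatter, and the same now holds for a swap of the ring itself. No evidence bears on this flat result.

Open, as far as these compounds go, is whether this end of the chain responds at all. A carboxylic acid or a primary amine at this place might still shift the number beyond the scatter.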